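Moving the trifluoromethyl group on the terminal aryl urea

The source may report more compounds than this note shows. Statements on the series, on what has been measured and on what is new or still open speak of the compounds shown alone.

Measured so far:
compound 1, `COc1cc2cc(Oc3ccc(NC(=O)Nc4ccc(C)cc4)cc3)c(C)nc2cc1OC`: 66.9%
compound 2, `COc1cc2cc(Oc3ccc(NC(=O)Nc4ccc(C(F)(F)F)cc4)cc3)c(C)nc2cc1OC`: 18.8%

In a functional assay on HOP-62 cells (Homo sapiens) for inhibition, read by sulforhodamine B assay, with a stated time of 48 h, tested at 10 uM (on this read-out lower numbers stand for a stronger effect and higher numbers for a weaker effect at the one concentration tested), compound 2 gives 18.8%, the lowest of the two numbers shown; compound 1 stands a number 48.1 percentage points lower from compound 1 to compound 2 (beyond the scatter) behind it, a step beyond the scatter. Compound 3, `COc1cc2cc(Oc3ccc(NC(=O)Nc4cccc(C(F)(F)F)c4)cc3)c(C)nc2cc1OC`, differs from compound 2 in one place: 3-(trifluoromethyl)phenyl in place of 4-(trifluoromethyl)phenyl on an amide-type nitrogen. Among the compounds with values here, no measured step bears directly on this change, since the single step from compound 1 to compound 2 swaps the group itself rather than its place on the ring, so the direction of any change for compound 3 in this assay is uncertain. Compound 3 is expected to remain among the stronger compounds, with a number 16.2 percentage points higher from compound 2 to compound 3 (beyond the scatter) estimated for the step. The estimate for compound 3 in this assay is 35%, within 12% to 65%.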

Compound 3, a percentage reported as activity, at one concentration (the size of the read-out at that concentration, not a potency): 25%
The estimate for compound 3 lay 10 percentage points above the measured number; low and high end bracket the measured number.
By their numbers in this assay, from the lowest: compounds 2 and 3 (each within the scatter of the next); then compound 1.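

In this assay, moving the group from 4-(trifluoromethyl)phenyl to 3-(trifluoromethyl)phenyl on the amide-type nitrogen gives a number 6.2 percentage points higher from compound 2 to compound 3 (within the scatter), so this assay does not separate the two placements. The large gain seen with trifluoromethyl in place of methyl is therefore not confined to compound 2, as the change to the 3-(trifluoromethyl)phenyl group gives a number 41.9 percentage points lower from compound 1 to compound 3 (beyond the scatter). Nothing available here offers an explanation for this result.

The compounds shown leave open whether a chlorine, a nitrile or a methoxy group on the terminal ring would match trifluoromethyl. With one concentration in one cell line, they also cannot tell whether compound 2 and compound 3 would stay alike in a full concentration series or in other cells.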